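Selenium to methylsulfanyl: an expected step from one limit

The source may hold more compounds than are shown below. What is called first, only, known or untested is meant among the compounds shown, and "the series" means these compounds.

compound 1 `COc1ccc(CNc2nc([SeH])nc3ccccc23)cc1`: > 100000 nM
compound 2 `[SeH]c1nc(NCc2ccccc2)c2ccccc2n1`: > 100000 nM

In a functional assay on CCRF-CEM cells (Homo sapiens) for cytotoxicity, read by MTT assay, with a stated time of 72 h (on this read-out lower numbers stand for stronger inhibition of growth and higher numbers for weaker inhibition of growth), compound 1 gives > 100000 nM, which is a limit of the assay rather than a number. Compound 2 likewise gives > 100000 nM, again a limit. The step that the two limits leave unreadable from compound 1 to compound 2 therefore cannot be read, as the limit of > 100000 nM in this assay, at which 2 of the 2 values shown sit, shows. Compound 3 `COc1ccc(CNc2nc(SC)nc3ccccc23)cc1` differs from compound 1 by a group of 2 heavy atoms (1 carbon, 1 sulfur; no ring) in place of one selenium atom, on an aromatic carbon. Among the compounds with values here, no measured step bears on this change, and compound 1 stands only at a limit. Compound 3 is therefore expected to stay near that limit, with a number no higher from compound 1 to compound 3 (the limit leaves the size open) no more than scatter. The estimate for compound 3 is 100000 nM, ranging from 30000 nM to 300000 nM.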

Compound 3, concentration for total growth inhibition: > 100000 nM
Compound 3 gave a limit, no number; the forecaster's own chance of this, stated with the estimate: 80%; the middle value sits exactly at the limit.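

Compound 1 and compound 3 both give a limit rather than a number, so no step can be read between them: the limit of > 100000 nM in this assay, at which 3 of the 3 values shown sit. Whether any of these changes affects growth inhibition at all stays open, with no number among the compounds shown.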